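The source may report more compounds than this note shows. Statements on the series, on what has been measured and on what is new or still open speak of the compounds shown alone.

Measured compounds:
- Compound 1, `CC1=C(C(=O)Nc2ccccc2)C(c2cn(-c3ccccc3)nc2-c2ccccc2)NC(=O)N1`: 80600 nM
- Compound 2, `CC1=C(C(=O)Nc2ccccc2)C(c2cn(-c3ccccc3)nc2-c2ccc(Cl)cc2)NC(=O)N1`: 65500 nM

Both numbers come from a functional assay on MCF7 cells (Homo sapiens) for inhibition, read by sulforhodamine B assay, with a stated time of 24 h; on this read-out lower numbers stand for stronger inhibition of growth and higher numbers for weaker inhibition of growth. Compound 2 has the lowest of the two numbers, but its neighbour compound 1 sits within the scatter, so no order between them can be claimed.

Compound 3, `CC1=C(C(=O)Nc2ccc(Cl)cc2)C(c2cn(-c3ccccc3)nc2-c2ccc(Cl)cc2)NC(=O)N1`, has not been measured yet. It differs from compound 2 in one place: chloro in place of hydrogen on an aromatic carbon. For the measured compounds named here, the only step that bears on this is the one from compound 1 to compound 2, also a chloro replacing a hydrogen on an aromatic carbon, though on a different ring; that step was a 1.2-fold lower number from compound 1 to compound 2 (0.09 log units; within the scatter). A second such exchange is therefore expected to give no step beyond the scatter in this assay, the estimated step being a 1.2-fold lower number from compound 2 to compound 3 (0.08 log units; within the scatter). Compound 3 is expected to give about 55000 nM, in a range from 25000 nM to 120000 nM.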

Compound 3, concentration for 50% growth inhibition: 56900 nM
Estimate against measurement, compound 3: 1.0-fold (0.01 log units) below, within the range that was stated.
By their numbers in this assay, from the lowest: compounds 3, 2 and 1 (each within the scatter of the next).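

The change from phenylcarbamoyl to (4-chlorophenyl)carbamoyl in this assay gives a 1.2-fold lower number from compound 2 to compound 3 (0.06 log units; within the scatter) and so leaves growth inhibition without a readable shift at this second site. With the earlier step on a different ring, a 1.2-fold lower number from compound 1 to compound 2 (0.09 log units; within the scatter) as well, a chloro in place of hydrogen has now stayed within the scatter on two separate rings of this series. Nothing measured here offers an explanation for the size of either step.

As far as these compounds go, whether this position responds to anything other than chloro remains open, since a methoxy group, an amine or a carboxylic acid in the same place could give a step beyond the scatter or none at all. With all the numbers this close, the compounds shown also leave open which part of the shared core, if any, governs the read-out in this assay.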